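Restoring a substituted phenyl at the triazole of compound 3

The source may report more compounds than this note shows. Statements on the series, on what has been measured and on what is new or still open speak of the compounds shown alone.

Measured compounds in an assay on isolated protein for displacement of a labelled ligand from D(4) dopamine receptor (Homo sapiens); a lower number here means a stronger inhibitor, a higher number a weaker inhibitor:
- compound 1 `COc1ccc(-c2cn(CCCCN3CCN(c4ccccc4OC)CC3)nn2)cc1` gives 395 nM
- compound 2 `COc1ccccc1N1CCN(CCCCn2cc(-c3ccc(N)cc3)nn2)CC1` gives 533 nM
- compound 3 `COc1ccccc1N1CCN(CCCCn2cc(-c3cccnc3)nn2)CC1` gives 1900 nM

All three share the same core, and they differ only in the aromatic group attached to the five-membered ring with three nitrogens. Compound 3 carries the highest number of the three, so it is the weakest binder here: the steps of a 4.8-fold higher number from compound 1 to compound 3 (0.68 log units; beyond the scatter) and a 3.6-fold higher number from compound 2 to compound 3 (0.55 log units; beyond the scatter) both lie beyond the scatter, while the step of a 1.3-fold higher number from compound 1 to compound 2 (0.13 log units; within the scatter) does not.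

Compound 4 `COc1ccccc1N1CCN(CCCCn2cc(-c3ccc(-c4cnco4)cc3)nn2)CC1` is not yet measured. Its change from compound 3 is 4-(1,3-oxazol-5-yl)phenyl in place of pyridin-3-yl on an aromatic carbon. The two informative steps are those from compound 1 and compound 2 to compound 3: in both, swapping a phenyl that carries a group in the 4-position for pyridin-3-yl raised the number modestly. The change to compound 4 moves back the other way, to a phenyl again bearing a group in the 4-position, now 1,3-oxazol-5-yl. The expectation is therefore a modest step downward in this assay, of about a 4.2-fold lower number from compound 3 to compound 4 (0.63 log units; beyond the scatter), bringing compound 4 near compound 1 and compound 2. Among the measured compounds shown here, the estimate for compound 4 is 450 nM, with a range from 150 nM to 1500 nM; the oxazolyl group itself has no precedent among the measured compounds, so this range is wide.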

Compound 4, inhibition constant: 426 nM
Estimate against measurement, compound 4: 1.1-fold (0.02 log units) above; the range from low to high includes it.
By their numbers in this assay, from the lowest: compounds 1, 4 and 2 (each within the scatter of the next); then compound 3.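

In this assay, placing 4-(1,3-oxazol-5-yl)phenyl on this aromatic carbon of the five-membered ring with three nitrogens, in place of pyridin-3-yl, gives a 4.5-fold lower number from compound 3 to compound 4 (0.65 log units; beyond the scatter), so this position takes a group of 11 heavy atoms and two aromatic rings with no loss of binding. The new group also cannot be told apart from the two smaller ones on the phenyl, with a 1.3-fold lower number from compound 2 to compound 4 (0.10 log units; within the scatter) and a 1.1-fold higher number from compound 1 to compound 4 (0.03 log units; within the scatter), so among these four compounds the three that carry a substituted phenyl sit together and compound 3, with pyridin-3-yl, stands alone at the weaker end. Nothing measured here explains these numbers or the gap between compound 3 and the other three.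

The compounds shown leave open whether the phenyl ring alone accounts for the stronger binding, which an unsubstituted phenyl at this place would test. Going by these compounds, it is also open whether the group on the phenyl can be varied this freely in general, for example with a carboxylic acid or a dimethylamino group in place of the 1,3-oxazol-5-yl.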